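The compounds below may be only part of what the source reports. "The series", "measured", "known", "first", "only" and "open" are said of these compounds alone.

Of the compounds shown here, two have been read so far in a functional assay on THP-1 cells (Homo sapiens) for inhibition, read by luminescence, with a stated time of 72 h, tested at 5 uM (on this read-out higher numbers stand for more inhibition of growth at the one concentration tested and lower numbers for less inhibition of growth), and the basis for any comparison is thin. Compound 1 (`C=CS(=O)(=O)NC/C=C/c1cc(OC)cc(O)c1C(=O)OCc1ccc(Br)cc1`) gives 31.2% and holds the lower of the two numbers. Compound 2 (`COc1cc(O)c(C(=O)OC(C)C)c(/C=C/CN2C(=O)C=CC2=O)c1`) gives 41.8% in this assay and lies higher by a gap beyond the scatter. These two compounds differ in more than one place, so their gap assigns nothing to any single group.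

Compound 3 (`C=CS(=O)(=O)NC/C=C/c1cc(OC)cc(O)c1C(=O)OCc1ccc(F)cc1`) is still unmeasured. It departs from compound 1 at one site: fluoro in place of bromo on an aromatic carbon with fluoro in place of bromo on an aromatic carbon, para to a large group. For the measured compounds named here, no measured pair shows this change or any other single change, so the data offer no direct precedent for its size. The expected a number 2.2 percentage points lower from compound 1 to compound 3 (within the scatter) is small, a slight downward drift that stays within the scatter. An estimate for compound 3 of 29% with an expected range of 15% to 43% is what these notes carry forward.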

Compound 3, percent growth inhibition at one concentration: 41.7%
Beside the measured number, compound 3's estimate is 12.7 percentage points below it; the measured number falls inside the stated range.
By their numbers in this assay, from the lowest: compound 1; then compounds 3 and 2 (each within the scatter of the next).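

In this assay, for the compounds shown here, fluoro in place of bromo on an aromatic carbon, para to a large group, gives a number 10.5 percentage points higher from compound 1 to compound 3 (beyond the scatter), and this is the first single-site step. It shows that this position responds to a one-atom exchange of one halogen for another, even though the exchange adds no ring, hydrogen-bond donor, hydrogen-bond acceptor or net charge, so the 4-bromobenzyl group cannot be treated as a fixed unit when reading the series. The step is modest, it rests on one pair, and no supporting measurement is available to say what lies behind it.

The compounds shown leave open where chloro, methyl, methoxy or plain hydrogen at the same place would fall relative to the bromo and fluoro pair, and so whether the change follows any trend or is a feature of these two halogens alone. They also leave open whether 4-bromophenyl to 4-fluorophenyl gives a similar step on a different background, for instance with an isopropyl group in place of the benzyl unit, or with an amine or a carboxylic acid on the chain of the shared core.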